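The source may report more compounds than this note shows. Statements on the series, on what has been measured and on what is new or still open speak of the compounds shown alone.

Compound 1 `COC[C@@H](C1CC1)n1cc(Cl)nc(Nc2cc(C)c(OC)nc2C)c1=O` gives 1.1 nM in an assay on frontal cortex for displacement of a labelled ligand from corticotropin-releasing factor receptor 1 (Rattus norvegicus); a higher number here means a weaker inhibitor, a lower number a stronger inhibitor.
Compound 2 `CC[C@H](C1CC1)n1cc(Cl)nc(Nc2cc(C)c(OC)nc2C)c1=O` gives 0.28 nM in this assay.
Compound 3 `COC[C@@H](C)n1cc(Cl)nc(Nc2cc(C)c(OC)nc2C)c1=O` gives 14 nM in this assay.

Compound 2 has the lowest number of the three. Compound 1 stands nearest to it, separated by a 3.9-fold lower number from compound 1 to compound 2 (0.59 log units; beyond the scatter), and compound 3 furthest, separated by a 50-fold higher number from compound 2 to compound 3 (1.70 log units; beyond the scatter). Compound 4 `CC[C@H](C1CC1)n1cc(C#N)nc(Nc2cc(C)c(OC)nc2C)c1=O` keeps the core and the 1-cyclopropylpropyl group of compound 2 and differs from it in one place: cyano in place of chloro on an aromatic carbon. For the measured compounds named here, none of the measured steps touches this position. All three of them concern the group on the aromatic nitrogen, and they were substantial, the third being a 13-fold higher number from compound 1 to compound 3 (1.10 log units; beyond the scatter), but they offer no guide to exchanging chloro for cyano on the ring. With nothing bearing on this change, the expectation for compound 4 in this assay is a 1.4-fold higher number from compound 2 to compound 4 (0.15 log units; within the scatter), which amounts to no step beyond the scatter. Compound 4 is therefore estimated at 0.4 nM, with a range from 0.12 nM to 1.5 nM.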

Compound 4, half-maximal inhibitory concentration: 1.7 nM
For compound 4 the middle estimate is 4.3-fold (0.63 log units) below the measured one, outside the stated range (above it).
By their numbers in this assay, from the lowest: compound 2; then compounds 1 and 4 (each within the scatter of the next); then compound 3.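

In this assay, for the compounds shown here, the aromatic carbon next to the ring nitrogen proves sensitive to its substituent, which the earlier compounds, all varied only on the aromatic nitrogen, could not show: cyano in place of chloro gives a 6.1-fold higher number from compound 2 to compound 4 (0.78 log units; beyond the scatter). With the 1-cyclopropylpropyl group held constant, this single pair favours chloro over cyano, although the step is modest and compound 4 still gives 1.7 nM. No available evidence accounts for the difference.

The compounds shown leave open how other groups at this position, such as fluoro, methyl or methoxy, would compare with chloro. They also leave open whether cyano in place of chloro would produce a step of similar size alongside the 1-cyclopropyl-2-methoxyethyl group of compound 1.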